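Fluoro added to the bromophenyl arm of compound 1

The source may report more compounds than this note shows. Statements on the series, on what has been measured and on what is new or still open speak of the compounds shown alone.

Among the measured compounds shown here, compound 1 `C=CCn1c(=O)/c(=C\c2cccc(Br)c2)[nH]c(=O)/c1=C\c1ccccc1OC` is the only member of this small set with a numerical result: in a functional assay on U-937 cells (Homo sapiens) for cytotoxicity, read by CCK-8 assay, with a stated time of 72 h (on this read-out lower numbers stand for stronger inhibition and higher numbers for weaker inhibition), compound 1 gives 1100 nM. Its two companions have no number at all. Compound 2 `C=CCn1c(=O)/c(=C\c2cccc(Br)c2)[nH]c(=O)/c1=C\c1cccc(Br)c1` is reported in this assay as "not active" (no number reported), and compound 3 `C=CCn1c(=O)/c(=C\c2cc(OC)c(OC)c(OC)c2)[nH]c(=O)/c1=C\c1cccc(Br)c1` is reported in this assay as "not active" (no number reported). For the measured compounds named here, no pair of measured compounds differs in a single place, so no step size is known from the data. Compound 4 `C=CCn1c(=O)/c(=C\c2cc(Br)ccc2F)[nH]c(=O)/c1=C\c1ccccc1OC` differs from compound 1 by one change: fluoro in place of hydrogen on an aromatic carbon. Compound 4 is expected to show a step of no change at the digits printed from compound 1 to compound 4 (within the scatter) that stays within the scatter of this assay. For compound 4 the expected value is 1100 nM, with a range from 400 nM to 3500 nM.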

Compound 4, half-maximal inhibitory concentration: 4700 nM
Compound 4: middle estimate off by 4.3-fold (0.63 log units), on the low side; measured number outside the range, above it.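

The bromophenyl arm of compound 1 proves sensitive to even a single added atom: in this assay, fluoro on an aromatic carbon, ortho to a large group and para to a bromo group, gives a 4.3-fold higher number from compound 1 to compound 4 (0.63 log units; beyond the scatter) and so weakens inhibition beyond the scatter. Among the compounds shown here, this is the first step that can be read in the set. Nothing shown here accounts for it. From the compounds shown here alone, whether an amine or a carboxylic acid at this place would move the number in the same direction remains open. So does whether this step would hold with the methoxyphenyl arm changed.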